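Notes on the series: from compound 1 to compound 4

The source may report more compounds than this note shows. Statements on the series, on what has been measured and on what is new or still open speak of the compounds shown alone.

Compound 1 `Cc1ccccc1-c1cc(C(C)(C)C)cc(C(C)C)c1CO` carries a 2-methylphenyl group on the shared core. In a functional assay on RKE cells for antagonist activity at Vasoactive intestinal polypeptide receptor 1 (Rattus norvegicus), read by HTRF and cAMP accumulation, with stated times of 10 min and 30 min (a lower number here means a stronger inhibitor, a higher number a weaker inhibitor), compound 1 gives > 50000 nM, which is a limit of the assay and not a number (the limit of > 50000 nM in this assay, at which 1 of the 3 values shown sits). Within the data shown here, compound 2 `CC(C)c1cc(C(C)(C)C)cc(-c2cccc(N(C)C)c2)c1CO` gives 310 nM and compound 3 `CSc1cccc(-c2cc(C(C)(C)C)cc(C(C)C)c2CO)c1` gives 170 nM; the one measured step, a 1.8-fold lower number from compound 2 to compound 3 (0.26 log units; within the scatter), is within the scatter, so these two values are read as equal.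

The unmeasured compound 4 `CC(C)c1cc(C(C)(C)C)cc(-c2cccc(Cl)c2)c1CO` differs from compound 1 by 3-chlorophenyl in place of 2-methylphenyl on an aromatic carbon. Among the measured compounds shown here, no measured step covers this exchange: the only step measured swaps one group for another on the phenyl ring while the 2-methylphenyl of compound 1 is never compared directly with any of them. The values of compounds 2 and 3 show that a substituted phenyl at this place, ortho to a hydroxymethyl group, can give a measured number, while compound 1 sits at a limit.

Compound 4 is therefore expected to fall near the values of compounds 2 and 3, an estimated 300 nM with a range from 80 nM to 1500 nM. The expected step of an at least 160-fold lower number from compound 1 to compound 4 (2.22 log units; beyond the scatter) is estimated from a limit and is accordingly uncertain.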

Compound 4, half-maximal inhibitory concentration: 100 nM
For compound 4 the middle estimate is 3.0-fold (0.48 log units) above the measured one; measured number inside the range.
By their numbers in this assay, from the lowest: compounds 4, 3 and 2 (each within the scatter of the next, the first and the last beyond it). At a limit, above all of these: compound 1.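

In this assay compound 1 remains a limit and not a number: the limit of > 50000 nM in this assay, at which 1 of the 4 values shown sits.

Among these compounds, exchanging 2-methylphenyl for 3-chlorophenyl at this place, ortho to a hydroxymethyl group, moves the series from that limit to a measured number, with a large change (an at least 500-fold lower number from compound 1 to compound 4 (2.69 log units; beyond the scatter)), and this is the first direct comparison with the 2-methylphenyl of compound 1. Among the groups on the phenyl ring, chloro and methylsulfanyl read as equal (a 1.7-fold lower number from compound 3 to compound 4 (0.23 log units; within the scatter)), whereas chloro and dimethylamino separate modestly (a 3.1-fold lower number from compound 2 to compound 4 (0.49 log units; beyond the scatter)), the only separation beyond the scatter among these three groups.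

The step from compound 1 to compound 4 alters both the group and its place on the phenyl ring, so the compounds shown do not separate these two changes, and a 3-methylphenyl or a 2-chlorophenyl would be needed to do so. Also open, going by these compounds, is how a carboxylic acid, a primary amine or a longer alkyl chain on the phenyl ring would read at this place.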